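The source may hold more compounds than are shown below. What is called first, only, known or untested is meant among the compounds shown, and "the series" means these compounds.

Values in a physicochemical assay for lipophilicity, using the shake flask method, in phosphate buffer, measured as octanol-water partition, with a stated time of 24 h, at pH 7.4, tested at 100 uM; a lower number here means a more polar compound, a higher number a more lipophilic compound:
compound 1 `COCCCOc1cc(C)c(-c2cccc(COc3ccc(OCC(=O)O)c(F)c3)c2)c(C)c1` gives "not determined" (no result reported)
compound 2 `Cc1cc(OCCOCc2ccccc2)cc(C)c1-c1cccc(COc2ccc(OCC(=O)O)c(F)c2)c1` gives "not determined" (no result reported)
compound 3 `Cc1cc(OCCCO)cc(C)c1-c1cccc(COc2ccc(OCC(=O)O)c(F)c2)c1` gives 2.73

Compound 3 holds the only number among these three, so it has no rank in the series and stands as the sole reference point. Compound 4 `COCCOc1cc(C)c(-c2cccc(COc3ccc(OCC(=O)O)c(F)c3)c2)c(C)c1` is still unmeasured and differs from compound 3 by one change: methoxy in place of hydroxymethyl on a saturated chain carbon, two bonds along the chain from an oxygen on an aromatic ring. The same difference reads as 3-hydroxypropoxy to 2-methoxyethoxy. Among the compounds with values here, no measured step bears on this change, so the expectation rests on the structural change alone: a moderate rise in this assay, beyond the scatter. The expected step is a number 0.47 log units higher from compound 3 to compound 4 (beyond the scatter). Compound 4 is estimated at 3.2, with an expected range of 2.85 to 3.55.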

Compound 4, distribution coefficient: 3.15
Compound 4: middle estimate off by 0.05 log units, on the high side; the measured number falls inside the stated range.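

In this assay, the exchange of 3-hydroxypropoxy for 2-methoxyethoxy gives the series its first measured step, a number 0.42 log units higher from compound 3 to compound 4 (beyond the scatter), and this puts a size on a change at this chain position. The two compounds hold the same atoms, joined differently: hydroxymethyl, with 1 hydrogen-bond donor, leaves, and methoxy, with 0 hydrogen-bond donors, enters. Nothing at hand accounts for the size of this step.

Still open, on these data alone, is how an amine or a carboxylic acid at this chain position would read in this assay. As far as these compounds go, a longer chain carrying the same methoxy is equally open.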